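Swapping the Amide Substituent at Near-Zero Inhibition

The compounds below may be only part of what the source reports. "The series", "measured", "known", "first", "only" and "open" are said of these compounds alone.

Compound 2 `Cc1cccc(Oc2ccnc(N3CCC[C@H]3C(=O)NCCCn3ccnc3)n2)c1` gives 2% in an assay on isolated protein for inhibition of MAP kinase-activated protein kinase 2 (Homo sapiens), read by HTRF, tested at 10 uM; a lower number here means less inhibition, a higher number more inhibition at the concentration tested (going by the name of the read-out). Within the data shown here, of the two numbers measured so far, that of compound 2 is the top one on paper, but this ranking carries no weight. Compound 1 `Cc1cccc(Oc2ccnc(N3CCC[C@H]3C(=O)NCc3cccnc3)n2)c1` gives 0% in this assay. The step of a number 2 percentage points higher from compound 1 to compound 2 (within the scatter) stays within the scatter, so the two compounds cannot be told apart.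

Compound 3 `COC(=O)C(CO)NC(=O)[C@@H]1CCCN1c1nccc(Oc2cccc(C)c2)n1` has not yet been measured. It differs from compound 2 in one place: 2-hydroxy-1-(methoxycarbonyl)ethyl in place of 3-(1H-imidazol-1-yl)propyl on an amide-type nitrogen. Among the measured compounds shown here, the only measured step that bears on this position is a number 2 percentage points higher from compound 1 to compound 2 (within the scatter), an earlier exchange on the same side of the amide, which changed nothing beyond the scatter. Both measured numbers sit close to no inhibition, and nothing in the data suggests a different outcome here. For compound 3 the expected step is therefore no change at the digits printed from compound 2 to compound 3 (within the scatter). Compound 3 is estimated at 2%, with a range from -8% to 14%.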

Compound 3, a percentage reported as inhibition, at one concentration (the size of the read-out at that concentration, not a potency): 1%
For compound 3 the middle estimate is 1 percentage points above the measured one; low and high end bracket the measured number.
By their numbers in this assay, from the lowest: compounds 1, 3 and 2 (each within the scatter of the next).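

In this assay, 2-hydroxy-1-(methoxycarbonyl)ethyl in place of 3-(1H-imidazol-1-yl)propyl gives a number 1 percentage points lower from compound 2 to compound 3 (within the scatter), and the same group in place of (pyridin-3-yl)methyl gives a number 1 percentage points higher from compound 1 to compound 3 (within the scatter), so the three compounds cannot be told apart. The two earlier groups each carried an aromatic ring, whereas the entering group has no ring, so a group without a ring on this amide-type nitrogen also reads close to no inhibition. No measurement at hand explains why any of these groups gives so little inhibition.

As far as these compounds go, whether a carboxylic acid in place of the methoxycarbonyl, an amine on the chain, or a longer chain would lift the number clear of the scatter remains open. From the compounds shown here alone, it is also open whether any group on this nitrogen can matter while the rest of the shared core stays the same.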